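Swapping an open side chain for 4-methylpiperazin-1-yl

This account rests on a few compounds, and the source may have more. Where it says the series, first, only, none or still open, it means among the compounds named here.

Values in an ADME assay on HOS cells (Homo sapiens) for cytotoxicity; on this read-out lower numbers stand for higher toxicity in this test and higher numbers for lower toxicity in this test
Compound 1 `CN(Cc1nc2ccccc2n1CCN)C1CCCc2cccnc21` gives > 20000 nM as a limit
Compound 2 `CN(Cc1nc2ccccc2n1CCCCN)C1CCCc2cccnc21` gives 2900 nM
Compound 3 `CN(Cc1nc2cccc(CNCCN)c2[nH]1)C1CCCc2cccnc21` gives > 20000 nM as a limit

Compound 3 stands at the limit of > 20000 nM in this assay, at which 2 of the 3 values shown sit, and is the starting point here. Compound 4 `CN1CCN(c2cccc3nc(CN(C)C4CCCc5cccnc54)[nH]c23)CC1` carries 4-methylpiperazin-1-yl in place of ((2-aminoethyl)amino)methyl on an aromatic carbon, and the count is 4-methylpiperazin-1-yl in place of ((2-aminoethyl)amino)methyl on an aromatic carbon in full. Within the data shown here, the one measured step is an at least 6.8-fold lower number from compound 1 to compound 2 (0.83 log units; beyond the scatter) and it lies at another place in the molecule, so it bears on this change only loosely. A modest fall in this assay is therefore expected, and the expected step is an at least 2.0-fold lower number from compound 3 to compound 4 (0.30 log units; that floor lies within the scatter) in size. For compound 4 the estimate is 10000 nM with an expected range from 3000 nM to 30000 nM overall.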

Compound 4, half-maximal cytotoxic concentration: 14000 nM
For compound 4 the middle estimate is 1.4-fold (0.15 log units) below the measured one; the range from low to high includes it.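

On this aromatic carbon, 4-methylpiperazin-1-yl in place of ((2-aminoethyl)amino)methyl gives an at least 1.4-fold lower number from compound 3 to compound 4 (0.15 log units; that floor lies within the scatter) in this assay. The swap to a ring with no hydrogen-bond donors therefore yields a measured number at this position, though the fall is not sure to lie beyond the scatter. The true size of the step stays unknown because compound 3 is only a limit: the limit of > 20000 nM in this assay, at which 2 of the 4 values shown sit.

Still open, on these data alone, is how a piperazin-1-yl without the methyl group, or a morpholin-4-yl, would read on this carbon. Either would help show whether the ring, its methyl group or its second nitrogen goes with the number.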